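The compounds below may be only part of what the source reports. "The series", "measured", "known", "first", "only" and "open" are said of these compounds alone.

Measured so far:
- compound 1 `O=C(NCc1ccc(S(=O)(=O)c2cccc(C(F)(F)F)c2)cc1)c1cc2cnccc2[nH]1`: 81%
- compound 2 `O=C(NCc1ccc(S(=O)(=O)c2ccc(F)cc2)cc1)c1cc2cnccc2[nH]1`: 91%

Both compounds share a core and a sulfonyl group bearing an aromatic ring, and both were tested in an ADME assay on microsomes from liver (Homo sapiens) for metabolic stability, read by LC-MS, with a stated time of 30 min, tested at 1 uM; a lower number here means that less of the compound is left, a higher number that more of the compound is left. Compound 2 stands highest of the two numbers in this assay. Among the measured compounds shown here, its nearest neighbour is compound 1, and the only measured step, a number 10 percentage points higher from compound 1 to compound 2 (within the scatter), swaps one aromatic ring on the sulfonyl sulfur for another without leaving the scatter.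

Compound 3 `O=C(NCc1ccc(S(=O)(=O)c2ccccc2)cc1)c1cc2cnccc2[nH]1` is the next compound to be measured. It differs from compound 2 by hydrogen in place of fluoro on an aromatic carbon. For the measured compounds named here, no measured step removes a fluoro atom in this way; the step from compound 1 to compound 2 is the only guide, it alters the same ring, and it stayed within the scatter. Because of a number 10 percentage points higher from compound 1 to compound 2 (within the scatter), no change beyond the scatter is expected here either. Compound 3 is therefore estimated at 85% in this assay, within a range from 70% to 96%, which means an expected step of a number 6 percentage points lower from compound 2 to compound 3 (within the scatter).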

Compound 3, percent of the compound remaining: 75%
For compound 3 the middle estimate is 10 percentage points above the measured one; low and high end bracket the measured number.
By their numbers in this assay, from the lowest: compounds 3, 1 and 2 (each within the scatter of the next, the first and the last beyond it).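

Among the compounds shown here, this is the first step in this assay to leave the scatter: removing a single fluoro atom, so that 4-fluorophenyl becomes phenyl, gives a number 16 percentage points lower from compound 2 to compound 3 (beyond the scatter) and shows that this one atom can be enough for a modest change. Hydrogen in place of the trifluoromethyl of the 3-(trifluoromethyl)phenyl group gives a number 6 percentage points lower from compound 1 to compound 3 (within the scatter), so among these compounds, taking a group off this ring does not always move the number beyond the scatter, although the two groups differ in both kind and place. No measurement at hand offers a reason for the size of either step.

The compounds shown leave open whether the higher number goes with fluoro in particular or would also appear with another group para to the large group, such as chloro, methyl or methoxy. They also leave open whether fluoro would give a step of this size at another carbon of the same ring, or whether a nitrile at the para place would do the same.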